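A few compounds are considered here, and "the series" means these few. Any claim that something is new, unique, unknown or untested is made for them only; others in the source may bear on it.

In a functional assay on HT-29 cells (Homo sapiens) for antiproliferative activity, read by sulforhodamine B assay, with a stated time of 72 h (a lower number here means a stronger inhibitor, a higher number a weaker inhibitor), compound 2, `N#Cc1ccc(NC(=S)N/N=C/c2ccc3ccccc3n2)cc1`, gives 15600 nM. Compound 3, `CN(C)C(=S)N/N=C/c1cnc2ccccc2n1`, which has a different structure, gives 450 nM, so compound 2 holds the higher of the two numbers. Compound 1, `Cc1cccc(NC(=S)N/N=C/c2ccc3ccccc3n2)c1`, gives only a limit of the assay, > 100000 nM.

The next compound, compound 4, `S=C(N/N=C/c1ccc2ccccc2n1)Nc1ccc(Cl)cc1`, has not yet been measured. It carries chloro in place of cyano on an aromatic carbon, para to a large group, turning 4-cyanophenyl into 4-chlorophenyl: chloro in place of cyano on an aromatic carbon.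

Among the measured compounds shown here, only one measured step bears on this group: an at least 6.4-fold lower number from compound 1 to compound 2 (0.80 log units; beyond the scatter). Its size is known only as a bound, and it replaces 3-methylphenyl with 4-cyanophenyl, so it shows that this group can matter in this assay but does not measure a swap at the same place. No step beyond the scatter is therefore expected, in either direction, though with wide uncertainty. The expected change is a 1.3-fold higher number from compound 2 to compound 4 (0.11 log units; within the scatter). For compound 4 the estimate is 20000 nM, with an expected range from 5000 nM to 80000 nM.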

Compound 4, half-maximal inhibitory concentration: 97200 nM
Beside the measured number, compound 4's estimate is 4.9-fold (0.69 log units) below it; measured number outside the range, above it.
By their numbers in this assay, from the lowest: compound 3; then compound 2; then compound 4. At a limit, above all of these: compound 1.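

In this assay, chloro in place of cyano on an aromatic carbon, para to a large group, gives a modest step, a 6.2-fold higher number from compound 2 to compound 4 (0.79 log units; beyond the scatter), with the rest of the molecule unchanged. The earlier step replaced 3-methylphenyl with 4-cyanophenyl and so could not isolate a swap at this one place, whereas this pair shows that the choice of group there matters on its own, with the nitrile-bearing compound 2 holding the lower number. The remaining step is only a bound and gives no size: an at least 1.0-fold lower number from compound 1 to compound 4 (0.01 log units; that floor lies within the scatter). Compound 1 stands only at a limit of the assay: the limit of > 100000 nM in this assay, at which 1 of the 4 values shown sits.

The compounds shown do not tell why cyano and chloro differ here. They also leave open how an amine or a carboxylic acid at this same place would compare with cyano.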